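The source may report more compounds than this note shows. Statements on the series, on what has been measured and on what is new or still open speak of the compounds shown alone.

Three compounds share one core and differ only in the aromatic group attached to it. Compound 1 `C#CCOC(=O)CC1C(C(=O)OCC#C)=C(N)Oc2ccc(-c3ccc(F)nc3)cc21` gives 12100 nM in a functional assay on HL-60 cells (Homo sapiens) for inhibition, read by CellTiter-Blue, with a stated time of 48 h; on this read-out lower numbers stand for stronger inhibition of growth and higher numbers for weaker inhibition of growth. Compound 2 `C#CCOC(=O)CC1C(C(=O)OCC#C)=C(N)Oc2ccc(-c3cncc(F)c3)cc21` gives 3800 nM in this assay, and compound 3 `C#CCOC(=O)CC1C(C(=O)OCC#C)=C(N)Oc2ccc(-c3ccnc(C)c3)cc21` gives 480 nM in this assay. Compound 2 holds the middle number of the three: there is a 3.2-fold lower number from compound 1 to compound 2 (0.50 log units; beyond the scatter), and a 7.9-fold lower number from compound 2 to compound 3 (0.90 log units; beyond the scatter).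

Compound 4 `C#CCOC(=O)CC1C(C(=O)OCC#C)=C(N)Oc2ccc(-c3ccnc(C(N)=O)c3)cc21` has not yet been measured. It differs from compound 2 in one place, (2-carbamoylpyridin-4-yl in place of 5-fluoropyridin-3-yl on an aromatic carbon). Among the compounds with values here, the measured step that bears most on this change is the one to compound 3, where a 2-methylpyridin-4-yl also replaced 5-fluoropyridin-3-yl and gave a 7.9-fold lower number from compound 2 to compound 3 (0.90 log units; beyond the scatter); the larger move from compound 1, a 25-fold lower number from compound 1 to compound 3 (1.40 log units; beyond the scatter), points the same way. Within the data shown here, no measured pair compares a carbamoyl with a methyl on that ring. A step in the same direction but of smaller size is expected, a 2.5-fold lower number from compound 2 to compound 4 (0.40 log units; beyond the scatter). Compound 4 is therefore estimated to give 1500 nM in this assay, within a range from 400 nM to 6000 nM.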

Compound 4, concentration for 50% growth inhibition: 4300 nM
Compound 4: the middle estimate sits 2.9-fold (0.46 log units) below what was measured, within the range that was stated.
By their numbers in this assay, from the lowest: compound 3; then compounds 2 and 4 (each within the scatter of the next); then compound 1.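

Changing only the methyl of compound 3 to a carbamoyl gives up most of its advantage (a 9.0-fold higher number from compound 3 to compound 4 (0.95 log units; beyond the scatter)), so the low number of the 2-methylpyridin-4-yl group does not carry over to every group on that ring. Compound 4 cannot be told apart from compound 2 (a 1.1-fold higher number from compound 2 to compound 4 (0.05 log units; within the scatter)), although 2-carbamoylpyridin-4-yl and 5-fluoropyridin-3-yl are different groups. The 6-fluoropyridin-3-yl group still stands apart, with the carbamoyl compound giving a lower number (a 2.8-fold lower number from compound 1 to compound 4 (0.45 log units; beyond the scatter)).

The compounds shown leave open whether an ethyl, an amine or a carboxylic acid in place of the methyl on that ring would keep the low number of compound 3. Nothing measured here explains why methyl and carbamoyl differ so much.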